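The compounds below may be only part of what the source reports. "The series", "measured", "known", "first", "only" and "open" are said of these compounds alone.

Compound 2 `CNc1nc(NCCCN(C)C)c2sc(-c3ccoc3)cc2n1` carries the shared core with a furan-3-yl group. Among the measured compounds shown here, in a physicochemical assay for solubility, at pH 2 (on this read-out lower numbers stand for lower solubility and higher numbers for higher solubility), compound 2 gives 221 ug/mL, the only plain number among the values shown. Compound 1 `CNc1nc(NCCCN(C)C)c2sc(-c3ccc(OC)nc3)cc2n1` differs from it by a 6-methoxypyridin-3-yl group in place of the furan-3-yl. In this assay compound 1 gives > 100 ug/mL, which is a limit of the assay rather than a number. The step from compound 1 to compound 2, a step that the limit leaves unreadable from compound 1 to compound 2, therefore has no readable size. Compound 3 `CNc1nc(NCCCN(C)C)c2sc(-c3cncnc3)cc2n1` has not yet been measured. It differs from compound 2 by pyrimidin-5-yl in place of furan-3-yl on an aromatic carbon, on an aromatic carbon of a five-membered aromatic ring with one sulfur, part of a fused system of two rings, next to the ring sulfur. For the measured compounds named here, no measured step with a readable size bears on this change, so the step of a 1.0-fold lower number from compound 2 to compound 3 (0.00 log units; within the scatter) is expected to stay within the scatter. Compound 3 is estimated to give 220 ug/mL, between 100 ug/mL and 500 ug/mL.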

Compound 3, solubility: 214 ug/mL
Beside the measured number, compound 3's estimate is 1.0-fold (0.01 log units) above it; the measured number falls inside the stated range.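

At this position, on an aromatic carbon next to the ring sulfur, this assay now has a readable step: pyrimidin-5-yl in place of furan-3-yl gives a 1.0-fold lower number from compound 2 to compound 3 (0.01 log units; within the scatter). For this one pair, then, a five-membered aromatic ring with 1 hetero atom and a six-membered aromatic ring with 2 hetero atoms give values within the scatter of each other. Compound 1 stands at a limit and not at a number, so its steps to the other two compounds cannot be read: the limit of > 100 ug/mL in this assay, at which 1 of the 3 values shown sits.

The compounds shown leave open whether a group of another kind at this place, such as an aliphatic amine or a carboxylic acid, would give a step beyond the scatter. They also leave open whether this result holds for other aromatic rings, since it rests on a single pair.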